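The source may hold more compounds than are shown below. What is called first, only, known or untested is meant among the compounds shown, and "the series" means these compounds.

In a functional assay on the whole organism (stomach) for inhibition, with Rattus norvegicus as the target, at a dose of 100 mg/kg by the intraduodenal route (a higher number here means more inhibition at the dose given (going by the name of the read-out), a lower number less inhibition), compound 1 `CC(Cn1ncccc1=O)C(=N)S` gives 40.3%. Compound 2 `N=C(S)CCn1ncccc1=O`, which carries hydrogen in place of methyl on a saturated chain carbon bound to a carbon with a double bond to nitrogen and a saturated chain carbon, gives 28.8% in this assay, so that a number 11.5 percentage points lower from compound 1 to compound 2 (beyond the scatter). Compound 3 `C/N=C(\S)C(C)Cn1ncccc1=O` differs from compound 1 in its core by a group of 4 heavy atoms (2 carbon, 1 nitrogen, 1 sulfur; no ring) in place of a group of 3 heavy atoms (1 carbon, 1 nitrogen, 1 sulfur; no ring), on a saturated chain carbon bound to two saturated chain carbons, and in this assay compound 3 gives 50.2%, so that a number 9.9 percentage points higher from compound 1 to compound 3 (within the scatter). Compound 4 `C/N=C(\S)CCn1ncccc1=O` is not yet measured; it stands to compound 3 as compound 2 stands to compound 1, through (hydrogen in place of methyl on a saturated chain carbon bound to a carbon with a double bond to nitrogen and a saturated chain carbon), the same change at the same place. Because the earlier step was a number 11.5 percentage points lower from compound 1 to compound 2 (beyond the scatter), a step of similar size is expected from compound 3, namely a number 11.2 percentage points lower from compound 3 to compound 4 (beyond the scatter). On that basis compound 4 is estimated to give 39% in this assay, with an expected range from 25% to 52%.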

Compound 4, a percentage reported as inhibition, in the whole organism at one dose (the size of the read-out at that dose, not a potency): 35.7%
Estimate against measurement, compound 4: 3.3 percentage points above; the measured number falls inside the stated range.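

Hydrogen in place of methyl on a saturated chain carbon bound to a carbon with a double bond to nitrogen and a saturated chain carbon gives, in this assay, a number 14.5 percentage points lower from compound 3 to compound 4 (beyond the scatter) and so carries over between the two cores at a like size: the same change on two cores in this assay, a number 11.5 percentage points lower (beyond the scatter) from compound 1 to compound 2 and a number 14.5 percentage points lower (beyond the scatter) from compound 3 to compound 4, 3 percentage points apart, within the scatter of two such steps. The larger group in place of the smaller one gives a number 6.9 percentage points higher from compound 2 to compound 4 (within the scatter) and stays within the scatter on both cores: the same change on two cores in this assay, a number 9.9 percentage points higher (within the scatter) from compound 1 to compound 3 and a number 6.9 percentage points higher (within the scatter) from compound 2 to compound 4, 3 percentage points apart, within the scatter of two such steps. This rests on two pairs at one dose, so it shows additive behaviour only for these four compounds and says nothing of other cores or of potency.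

The compounds shown leave open whether an ethyl group or a longer chain at that carbon would continue the trend. They also leave open what an amine or a carboxylic acid would do in place of the larger group.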